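This account rests on a few compounds, and the source may have more. Where it says the series, first, only, none or still open, it means among the compounds named here.

Compound 1 `CC(=O)Oc1ccc(C(=O)Nc2cc3ccc(OCC4CCCN(C)C4)c(C)c3oc2=O)cc1CC=C(C)C`: 1650 nM
Compound 2 `CC(C)=CCc1cc(C(=O)Nc2cc3ccc(OCC4CCCNC4)c(C)c3oc2=O)ccc1O`: 790 nM
Compound 3 `CCCN(CCC)CCCOc1ccc2cc(NC(=O)c3ccc(O)c(CC=C(C)C)c3)c(=O)oc2c1C`: > 50000 nM (a limit of the assay, not a number)

In a functional assay on MCF7 cells (Homo sapiens) for antiproliferative activity (on this read-out higher numbers stand for weaker inhibition and lower numbers for stronger inhibition), compound 3 stands only at the limit (the limit of > 50000 nM in this assay, at which 1 of the 3 values shown sits), so no exact number is known for it. Compound 4 `CC(C)=CCc1cc(C(=O)Nc2cc3ccc(OCCCN(C)C4CCCCC4)c(C)c3oc2=O)ccc1O` differs from compound 3 in one place: cyclohexyl(methyl)amino in place of dipropylamino on a saturated chain carbon, three bonds along the chain from an oxygen on an aromatic ring. Going by the values given here, only one measured step separates two compounds by a single change, an at least 63-fold higher number from compound 2 to compound 3 (1.80 log units; beyond the scatter), and it concerns a different change, so no measured step directly matches the present one. With compound 3 at the limit, the expected step of an at least 2.0-fold lower number from compound 3 to compound 4 (0.30 log units; that floor lies within the scatter) can only be stated as a guess, and a weak result close to the limit remains likely. Compound 4 is estimated at 25000 nM, with a range from 4000 nM to 80000 nM.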

Compound 4, half-maximal inhibitory concentration: 1080 nM
Beside the measured number, compound 4's estimate is 23-fold (1.36 log units) above it; measured number outside the range, below it.
By their numbers in this assay, from the lowest: compounds 2, 4 and 1 (each within the scatter of the next, the first and the last beyond it). At a limit, above all of these: compound 3.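

In this assay, the amine carried on the 3-carbon propyl chain makes a large difference: cyclohexyl(methyl)amino in place of dipropylamino gives an at least 46-fold lower number from compound 3 to compound 4 (1.66 log units; beyond the scatter). Compound 3 stands at a limit, so this size is only a floor: the limit of > 50000 nM in this assay, at which 1 of the 4 values shown sits. The step of a 1.4-fold higher number from compound 2 to compound 4 (0.14 log units; within the scatter) shows that a chain amine can match the piperidin-3-yl group of compound 2, so the loss seen in compound 3 does not extend to compound 4.

Going by these compounds, it remains open whether the cyclohexyl ring itself matters, or any amine other than dipropylamino would do. A dimethylamino or morpholine group in the same place would test this.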